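The source may report more compounds than this note shows. Statements on the series, on what has been measured and on what is new or still open speak of the compounds shown alone.

Compound 1 `CS(=O)(=O)Oc1c(C(=O)NCc2ccc(F)cc2)nc(Br)c2cccnc12` gives > 20000 nM in a functional assay on MDA-MB-435 cells (Homo sapiens) for cytotoxicity, read by MTT assay, with a stated time of 72 h (a higher number here means a weaker inhibitor, a lower number a stronger inhibitor), and this is a limit of the assay rather than a number. Compound 1 therefore stands at the limit of > 20000 nM in this assay, at which 1 of the 3 values shown sits. Two relatives give real numbers: compound 2 `CC(C)(C)OC(=O)N1CCN(c2c(C(=O)NCc3ccc(F)cc3)nc(Br)c3cccnc23)CC1` reads 10000 nM, and compound 3 `COc1cccc(CNC(=O)c2nc(Br)c3cccnc3c2N[C@H]2CC[C@H](N)CC2)c1` reads 7000 nM. Each of these two carries a nitrogen-linked group on the aromatic carbon where compound 1 holds its (methylsulfonyl)oxy group, although they also differ from compound 1 elsewhere.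

Compound 4 `O=C(NCc1ccc(F)cc1)c1nc(Br)c2cccnc2c1NCCO` makes a single change to compound 1: (2-hydroxyethyl)amino in place of (methylsulfonyl)oxy on an aromatic carbon. The swap puts (2-hydroxyethyl)amino in place of (methylsulfonyl)oxy on an aromatic carbon, para to a bromo group. For the measured compounds named here, no measured pair isolates this swap, so any forecast is rough. Going by compound 2 at 10000 nM and compound 3 at 7000 nM, a modest move toward stronger inhibition is expected in this assay, with an at least 1.8-fold lower number from compound 1 to compound 4 (0.25 log units; that floor lies within the scatter) as the estimated step. For compound 4 the estimated value is 11000 nM, with an expected range from 4500 nM to 27000 nM.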

Compound 4, half-maximal inhibitory concentration: > 20000 nM
Compound 4: a limit, no number; the forecaster's own chance of this, stated with the estimate: 35%; at least 1.8-fold (0.25 log units) between middle value and limit.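

Compound 1 and compound 4 both sit at a limit of this assay rather than at a number, so no step between them can be read: the limit of > 20000 nM in this assay, at which 2 of the 4 values shown sit.

The compounds shown leave open whether (2-hydroxyethyl)amino in place of (methylsulfonyl)oxy changes the value at all, and by how much.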